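The compounds below may be only part of what the source reports. "The series", "measured", "known", "first", "only" and "open" are said of these compounds alone.

Of the compounds shown here, three have so far been measured in a functional assay on HEK293 cells for agonist activity at G-protein coupled receptor 39 (Homo sapiens), read by scintillation proximity assay and inositol phosphate accumulation, with a stated time of 75 min; on this read-out higher numbers stand for an effect only at larger amounts of compound and lower numbers for an effect already at smaller amounts. Compound 1 `Cc1nn(-c2ncnc3nc[nH]c23)c2c1C(OCc1ccc(Cl)cc1Cl)CC(=O)N2` gives 243 nM, and compound 2 `CCCCCCCCOC1CC(=O)Nc2c1c(C)nn2-c1ncnc2nc[nH]c12` gives 388 nM, the step of a 1.6-fold higher number from compound 1 to compound 2 (0.20 log units; within the scatter) lying within the scatter. Compound 3 `Cc1cc(C)nc(-n2nc(C)c3c2NC(=O)CC3c2ccc(COc3cccc(Cl)c3)cc2)n1`, built on a different core, gives 3000 nM. Among these three numbers compound 2 stands second highest: its nearest neighbour is compound 1, whose number is lower but within the scatter, while compound 3 lies furthest away, with a higher number beyond the scatter.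

Compound 4 `Cc1nn(-c2ncnc3nc[nH]c23)c2c1C(OCc1ccc(C#N)cc1)CC(=O)N2` has not yet been measured. It differs from compound 2 in one place: 4-cyanophenyl in place of heptyl on a saturated chain carbon bound to an oxygen on a saturated carbon. Within the data shown here, only one measured step touches this position, namely a 1.6-fold higher number from compound 1 to compound 2 (0.20 log units; within the scatter), in which a 2,4-dichlorophenyl group was exchanged for heptyl on the saturated chain carbon bound to an oxygen on a saturated carbon, and the number stayed within the scatter. Compound 4 brings an aromatic ring back to that carbon, this time 4-cyanophenyl. With a single small step of this kind on record, no change beyond the scatter is expected in this assay. Compound 4 is therefore estimated to give about 300 nM in this assay, within a range from 100 nM to 1000 nM, corresponding to an expected step of a 1.3-fold lower number from compound 2 to compound 4 (0.11 log units; within the scatter).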

Compound 4, half-maximal effective concentration: 60 nM
Compound 4: middle estimate off by 5.0-fold (0.70 log units), on the high side; the whole stated range lies above it.
By their numbers in this assay, from the lowest: compound 4; then compounds 1 and 2 (each within the scatter of the next); then compound 3.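

In this assay, 4-cyanophenyl in place of heptyl gives a 6.5-fold lower number from compound 2 to compound 4 (0.81 log units; beyond the scatter), and 4-cyanophenyl in place of 2,4-dichlorophenyl gives a 4.1-fold lower number from compound 1 to compound 4 (0.61 log units; beyond the scatter), so the position that had seemed indifferent in the exchange between compound 1 and compound 2 does respond to the group placed there. An aromatic ring on this carbon is not enough to account for the result: compound 1 also carries one, yet its number lies within the scatter of that of compound 2, which has the open heptyl chain, and only compound 4, with its nitrile-bearing ring, stands apart from both. No measurement is available that would explain why this group gives the lower number.

From the compounds shown here alone, it remains open how a plain phenyl or a 4-chlorophenyl on this carbon would compare with 4-cyanophenyl, and therefore whether the nitrile itself accounts for the step. Also open, going by these compounds, is how a ring carrying a carboxylic acid or an amine at that same 4-position would behave, and whether 4-cyanophenyl would give a similar step with a shorter link to the oxygen.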